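Opening the Oxane Ring on the Amide Nitrogen

The source may hold more compounds than are shown below. What is called first, only, known or untested is meant among the compounds shown, and "the series" means these compounds.

Compound 1 `O=C(CN(C(=O)c1ccc(-c2ccccn2)cc1)C1CCCOC1)Nc1cc(F)cc(F)c1` and compound 2 `O=C(CN(C(=O)c1ccc(-c2ccccn2)cc1)C1CCOCC1)Nc1cc(F)cc(F)c1` share one core and differ only in the ring carried on the amide-type nitrogen. In a physicochemical assay for solubility, read by chemiluminescence (on this read-out higher numbers stand for higher solubility and lower numbers for lower solubility), compound 1 gives 56 ug/mL, and compound 2 gives 99 ug/mL. The step of a 1.8-fold higher number from compound 1 to compound 2 (0.25 log units; within the scatter) is within the scatter, so compound 2, though it holds the higher of the two numbers, cannot be called more soluble than compound 1. Compound 3 `CCC(COC)N(CC(=O)Nc1cc(F)cc(F)c1)C(=O)c1ccc(-c2ccccn2)cc1` departs from compound 2 by a change of another kind: 1-(methoxymethyl)propyl in place of oxan-4-yl on an amide-type nitrogen. Among the measured compounds shown here, no measured step bears on exchanging a ring for a chain at this position; the only step known, oxan-4-yl for oxan-3-yl, stayed within the scatter. The account therefore expects no step beyond the scatter, a 1.4-fold lower number from compound 2 to compound 3 (0.15 log units; within the scatter), in this assay. For compound 3 the estimated value in this assay is 70 ug/mL, with a range from 30 ug/mL to 170 ug/mL.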

Compound 3, solubility: 24 ug/mL
Estimate against measurement, compound 3: 2.9-fold (0.46 log units) above; the measured number lies below the stated range.
By their numbers in this assay, from the lowest: compound 3; then compounds 1 and 2 (each within the scatter of the next).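

In this assay, among the compounds shown here, the exchange of a ring for an open chain on the amide-type nitrogen is the first change at this position to go beyond the scatter: 1-(methoxymethyl)propyl in place of oxan-4-yl brings a 4.1-fold lower number from compound 2 to compound 3 (0.62 log units; beyond the scatter) and in place of oxan-3-yl brings a 2.3-fold lower number from compound 1 to compound 3 (0.37 log units; beyond the scatter). The two oxane isomers lie within the scatter of each other, whereas the chain falls beyond it against both, so this position responds to the change even though 1-(methoxymethyl)propyl matches oxan-4-yl in its count of heavy atoms and hydrogen-bond acceptors. Nothing measured here bears on the reason for these steps.

The compounds shown leave open whether the lower number goes with the open chain as such or with its branching, and an unbranched chain such as 3-methoxypropyl would separate the two. They also leave open how a ring carrying an amine would read at this position in this assay.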